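Swapping a hydroxyphenyl arm on a pyridine-bearing core

The compounds below may be only part of what the source reports. "The series", "measured", "known", "first", "only" and "open" are said of these compounds alone.

Measured so far:
compound 1, `Oc1ccc(-c2cc(-c3ccoc3)cc(-c3cccc(O)c3)n2)cc1`, 37.4%
compound 2, `Oc1ccc(-c2cc(-c3cccnc3)cc(-c3ccccc3O)n2)cc1`, 1.5%
compound 3, `Oc1cccc(-c2cc(-c3cccnc3)cc(-c3cccc(O)c3)n2)c1`, 2.1%

In an assay on isolated protein for inhibition of DNA topoisomerase 1 (Homo sapiens), with a stated time of 30 min, tested at 100 uM (a higher number here means a stronger effect of the compound at the concentration tested, a lower number a weaker effect), compound 3 gives 2.1%. This puts compound 3 second highest of the three numbers, but its nearest neighbour, compound 2, lies within the scatter of it, so the two cannot be told apart. Compound 1, the furthest, sits well beyond the scatter above compound 3.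

Compound 4, `Oc1ccc(-c2cc(-c3cccnc3)cc(-c3cccc(O)c3)n2)cc1`, has not yet been measured in this assay. It keeps all atoms of compound 3 but joins them differently: 4-hydroxyphenyl in place of 3-hydroxyphenyl on an aromatic carbon. Going by the values given here, no measured pair differs by this change alone, so the expected size of the step rests on what the three numbers show. Among the compounds with values here, compound 2, which carries a 4-hydroxyphenyl group and a pyridin-3-yl group, gives 1.5%, and compound 3, also with pyridin-3-yl, gives 2.1%; the only high number, 37.4% for compound 1, comes with a furan-3-yl group instead. Compound 4 is therefore expected to stay low, with a step of a number 4.9 percentage points higher from compound 3 to compound 4 (within the scatter) that is expected to lie within the scatter. The estimate for compound 4 is 7%, expected between 0% and 28%.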

Compound 4, a percentage reported as inhibition, at one concentration (the size of the read-out at that concentration, not a potency): 5.9%
For compound 4 the middle estimate is 1.1 percentage points above the measured one, and the stated range covers the measured number.
By their numbers in this assay, from the lowest: compounds 2, 3 and 4 (each within the scatter of the next); then compound 1.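

In this assay, 4-hydroxyphenyl in place of 3-hydroxyphenyl gives a number 3.8 percentage points higher from compound 3 to compound 4 (within the scatter) and 3-hydroxyphenyl in place of 2-hydroxyphenyl gives a number 4.4 percentage points higher from compound 2 to compound 4 (within the scatter) on the other arm, so with pyridin-3-yl present, these changes of hydroxyl placement leave the three compounds indistinguishable. Going by these compounds alone, the new compound also gives the first single-place comparison for the earlier high number: pyridin-3-yl in place of furan-3-yl gives a number 31.5 percentage points lower from compound 1 to compound 4 (beyond the scatter) in this pair, so here the large change follows that group and not the hydroxyphenyl arms. Nothing at hand explains this difference.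

Among these compounds only compound 1 carries furan-3-yl, so it remains open whether hydroxyl placement matters alongside that group. Also open, on these data alone, is what an amine or a carboxylic acid would give in place of the hydroxyl on either arm.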